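Trading a methylpyridine amide for an aminopyridine amide

A few compounds are considered here, and "the series" means these few. Any claim that something is new, unique, unknown or untested is made for them only; others in the source may bear on it.

Compound 1 `CCOc1cc(CN2CCC[C@@H](NC(=O)c3cncc(C)c3)CC2)ccc1Cl` was taken into a physicochemical assay for lipophilicity, read by spectrophotometry, measured as octanol-water partition, at pH 7.4 (on this read-out lower numbers stand for lower lipophilicity and higher numbers for higher lipophilicity), but in this assay compound 1 has only the entry "not determined" (no result reported), with no number behind it. For the measured compounds named here, compound 2 `CCOc1cc(CN2CCC(NC(=O)c3cncc(C)c3)CC2)ccc1C` is the only member of this set with a number: in this assay compound 2 gives 3.03, and with nothing else measured it stands alone, neither high nor low relative to a neighbour. Compound 3 `CCOc1cc(CN2CCC(NC(=O)c3ccc(N)nc3)CC2)ccc1C` keeps the shared core of compound 2 and changes one group: 6-aminopyridin-3-yl in place of 5-methylpyridin-3-yl on a carbonyl carbon. The group that enters brings one hydrogen-bond donor and a second hydrogen-bond acceptor where the group that leaves had none and one. Going by the values given here, no measured pair in this set shows what such a swap does here, so the size of the step must be judged from the change itself. Compound 3 is expected to fall clearly, by a step of a number 1.43 log units lower from compound 2 to compound 3 (beyond the scatter), well beyond the usual scatter, when counted from compound 2 at 3.03. For compound 3 the estimated value is 1.6, with a likely range from 1 to 2.2.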

Compound 3, distribution coefficient: 2.24
Compound 3: middle estimate off by 0.64 log units, on the low side; the measured number lies above the stated range.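

In this assay, for the compounds shown here, the replacement of 5-methylpyridin-3-yl by 6-aminopyridin-3-yl on a carbonyl carbon gives the first step that can be read in this set, a number 0.79 log units lower from compound 2 to compound 3 (beyond the scatter), and it is a modest one. It shows that the read-out at this position moves with this exchange even though the heavy-atom count of the group stays the same, the entering group differing by a ring carbon traded for nitrogen and by the hydrogen-bond donor and extra acceptor counted for it. Nothing measured in the material at hand explains why the step has this size.

As far as these compounds go, since this is a single pair, it stays open whether a step of similar size would follow from a hydroxyl or a dimethylamino group carried on the pyridine ring in place of the amine, or from a carboxylic acid there. Going by these compounds alone, compound 1 has no number in this assay, so no step involving it can be read, and what its different core would do under the same exchange also stays open.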